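A few compounds are considered here, and "the series" means these few. Any claim that something is new, unique, unknown or untested is made for them only; others in the source may bear on it.

Measured so far:
- compound 1 `CC(C)(C)c1cc(NC(=O)[C@@H]2CCCCN2Cc2ccc(Cl)cc2)no1`: 0.15 h
- compound 2 `CC(C)(C)c1cc(NC(=O)[C@@H]2CCCCN2C(=O)C2CCCCC2)no1`: 0.483 h

For the measured compounds named here, in an ADME assay (liver) for metabolic stability, with Liver microsome (Homo sapiens) as the target, read by LC-MS, using microsomes and NADPH, tested at 1 uM (a lower number here means that the compound disappears faster, a higher number that the compound lasts longer), compound 2 gives the higher of the two numbers; the only step to it, a 3.2-fold higher number from compound 1 to compound 2 (0.51 log units; beyond the scatter), is modest but beyond the scatter. Compound 3 `CC(=O)N1CCN(C(=O)N2CCCC[C@H]2C(=O)Nc2cc(C(C)(C)C)on2)CC1` has not yet been measured; it differs from compound 2 in one place, (4-acetylpiperazin-1-yl in place of cyclohexyl on a carbonyl carbon). Going by the values given here, no measured step changes the group on that carbonyl carbon, so nothing bears directly on it. Among the compounds with values here, the single known step at the ring nitrogen, a 3.2-fold higher number from compound 1 to compound 2 (0.51 log units; beyond the scatter), shows the series moving only modestly under a larger change there. For compound 3 a step no larger than that is expected, more likely upward than downward, and possibly none beyond the scatter, that is a 1.4-fold higher number from compound 2 to compound 3 (0.16 log units; within the scatter). Compound 3 is therefore estimated at 0.7 h in this assay, with a range of 0.35 h to 1.5 h.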

Compound 3, half-life: > 2 h
Compound 3: no number, only a limit (the forecaster's own chance of this, stated with the estimate: 10%); middle value at least 2.8-fold (0.45 log units) away from the limit.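

In this assay the exchange of cyclohexyl for 4-acetylpiperazin-1-yl on a carbonyl carbon gives an at least 4.1-fold higher number from compound 2 to compound 3 (0.61 log units; beyond the scatter) and so shows that this position, untouched by the earlier step at the ring nitrogen, can move the number beyond the scatter. Compound 3 stands at > 2 h, which is a limit of the assay and not a number, so the step has a floor but no known top: the limit of > 2 h in this assay, at which 1 of the 3 values shown sits.

Going by these compounds, compound 2 and compound 3 do not show whether the step follows from the ring with 2 hetero atoms or from the acetyl, and the true half-life of compound 3 stays open. An unsubstituted piperazine, an amine, or a morpholine on the same carbonyl carbon would bear on the first of these questions.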